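Removing a ring methyl in a small fused aminopyrazole series

A few compounds are considered here, and "the series" means these few. Any claim that something is new, unique, unknown or untested is made for them only; others in the source may bear on it.

Measured compounds:
compound 1 `Cc1cc2[nH]nc(N)c2c(N2CCCCC2)n1` — 43%
compound 2 `Cc1cc2c(c(N)nn2C)c(N2CCCCC2)n1` — -152%
compound 3 `Cc1cc2c(cn1)c(N)nn2C` — -59%

All three were tested in an assay on isolated protein for inhibition of protein kinase C zeta type (Homo sapiens), read by mobility shift assay, tested at 30 uM; a higher number here means more inhibition at the concentration tested (going by the name of the read-out), a lower number less inhibition. Compound 1 gives 43%, while compound 2 gives -152% and compound 3 gives -59%; the two negative numbers mean that, at the concentration used, the signal moved the opposite way from inhibition.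

Compound 1 and compound 2 differ in one place: hydrogen in place of methyl on an aromatic nitrogen. That single change produced a number 195 percentage points higher from compound 2 to compound 1 (beyond the scatter). The two cores on which this change is made differ as follows: hydrogen in place of piperidin-1-yl on an aromatic carbon, and that difference alone gave a number 93 percentage points higher from compound 2 to compound 3 (beyond the scatter).

Compound 4 `Cc1cc2[nH]nc(N)c2cn1` has not yet been measured. For the measured compounds named here, it differs from compound 3 by hydrogen in place of methyl on an aromatic nitrogen, which is the same change as the one from compound 2 to compound 1, made at a place described in identical words. Because compound 2 to compound 1 showed a number 195 percentage points higher from compound 2 to compound 1 (beyond the scatter), the step from compound 3 to compound 4 is expected to be a large rise as well, estimated at a number 99 percentage points higher from compound 3 to compound 4 (beyond the scatter), although a read-out of this kind cannot keep climbing without bound, so the expectation is held somewhat below a full repeat. For compound 4 the estimate in this assay is 40%, with a likely range from -10% to 85%.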

Compound 4, a percentage reported as inhibition, at one concentration (the size of the read-out at that concentration, not a potency): -275%
For compound 4 the middle estimate is 315 percentage points above the measured one, and the stated range ends above it.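

In this assay, the swap of methyl for hydrogen on the aromatic nitrogen does not carry over from one core to the other, and the direction of the step reverses: the same change on two cores in this assay, a number 195 percentage points higher (beyond the scatter) from compound 2 to compound 1 and a number 216 percentage points lower (beyond the scatter) from compound 3 to compound 4, 411 percentage points apart, beyond the scatter of two such steps

On the core that lacks the piperidin-1-yl group, the change gives a number 216 percentage points lower from compound 3 to compound 4 (beyond the scatter), so the rise seen on the core that carries this group cannot be assumed to apply without it. This does not explain the reversal, and it offers no rule for other cores, since each core is represented by a single pair of compounds and compound 4, at -275%, joins compound 2 and compound 3 in giving a negative number rather than measurable inhibition.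

The compounds shown leave open whether the rise from this swap depends on the piperidin-1-yl group in particular, or would also appear with a morpholine ring, a simple amine or a longer carbon chain in its place. They also leave open how a larger group on the aromatic nitrogen, such as ethyl or a longer chain, would behave on either core, compared with the methyl and hydrogen seen so far.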